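The compounds below may be only part of what the source reports. "The series", "measured", "known", "first", "only" and "open" are said of these compounds alone.

In an ADME assay for permeability, using PAMPA, at pH 7.4 (on this read-out higher numbers stand for higher permeability and lower numbers for lower permeability), compound 1 (`Cc1ccc(-c2nc3ccccc3s2)cc1NC(=O)c1cc([N+](=O)[O-])c(N(C)C)cc1Cl`) gives < 1 10^-6 cm/s, which is a limit of the assay and not a number. It therefore stands at the limit of < 1 10^-6 cm/s in this assay, at which 1 of the 3 values shown sits.

Two related compounds give numbers. Compound 2 (`COc1ccc(-c2nc3ccccc3o2)cc1NC(=O)c1cc([N+](=O)[O-])ccc1Cl`) gives 274 10^-6 cm/s, and compound 3 (`O=C(Nc1ccc(F)c(-c2nc3ccccc3s2)c1)c1cc([N+](=O)[O-])ccc1Cl`) gives 17 10^-6 cm/s. Among the compounds with values here, neither carries the dimethylamino group, but both also differ from compound 1 elsewhere, so no measured step isolates that group.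

Compound 4 (`Cc1ccc(-c2nc3ccccc3s2)cc1NC(=O)c1cc([N+](=O)[O-])ccc1Cl`) differs from compound 1 by a single change, (hydrogen in place of dimethylamino on an aromatic carbon), with hydrogen in place of dimethylamino on an aromatic carbon. Compound 4 thus shares the hydrogen at that carbon with the two compounds that give numbers, and a rise beyond the scatter is expected in this assay, with compound 3 at 17 10^-6 cm/s as the main guide. The expected change is an at least 30-fold higher number from compound 1 to compound 4 (1.47 log units; beyond the scatter). For compound 4 the estimated value is 30 10^-6 cm/s, with an expected range from 6 10^-6 cm/s to 150 10^-6 cm/s.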

Compound 4, apparent permeability: 41 10^-6 cm/s
Estimate against measurement, compound 4: 1.4-fold (0.14 log units) below; low and high end bracket the measured number.
By their numbers in this assay, from the lowest: compound 3; then compound 4; then compound 2. At a limit, below all of these: compound 1.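

Within the data shown here, the single change isolates this position for the first time: in this assay, hydrogen in place of dimethylamino on the aromatic carbon ortho to a nitro group gives an at least 41-fold higher number from compound 1 to compound 4 (1.61 log units; beyond the scatter). Compound 1 stands at a limit and not at a number: the limit of < 1 10^-6 cm/s in this assay, at which 1 of the 4 values shown sits. With hydrogen on this carbon and the rest of the structure unchanged, compound 4 gives a true number, 41 10^-6 cm/s. Within this pair, the dimethylamino group alone separates a limit from a measurable value.

The compounds shown leave open whether methylamino, an amino group or methoxy on this carbon would stay close to compound 4 or fall to the limit of compound 1. They also leave open whether dimethylamino at this place would have the same outcome on the cores of compound 2 and compound 3.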